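Removing a Ring Hydroxy: From Compound 2 to Compound 3

A few compounds are considered here, and "the series" means these few. Any claim that something is new, unique, unknown or untested is made for them only; others in the source may bear on it.

compound 1, `CC(=O)c1ccc(NC(=O)C2CC(O)CN2S(=O)(=O)c2ccc(C)cc2)cc1`: 12.7% in a functional assay for inhibition, read by spectrophotometry, with a stated time of 20 min, tested at 3 mg/mL; a higher number here means a stronger effect of the compound at the concentration tested, a lower number a weaker effect
compound 2, `CC(=O)c1ccc(NC(=O)C2CC(O)CN2S(=O)(=O)c2ccc([N+](=O)[O-])cc2)cc1`: 58.7% in this assay

For the measured compounds named here, of the two numbers, compound 2 stands highest; the nearest is compound 1, and the single measured step, a number 46 percentage points higher from compound 1 to compound 2 (beyond the scatter), came with nitro in place of methyl on an aromatic carbon. Compound 3, `CC(=O)c1ccc(NC(=O)C2CCCN2S(=O)(=O)c2ccc([N+](=O)[O-])cc2)cc1`, differs from compound 2 by hydrogen in place of hydroxy on a saturated ring carbon. Going by the values given here, no measured step touches that ring position, so nothing measured bears on this change. The expected step is a number 8.7 percentage points lower from compound 2 to compound 3 (within the scatter), within the scatter. Compound 3 is therefore estimated at 50%, between 25% and 75%, in this assay.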

Compound 3, a percentage reported as inhibition, at one concentration (the size of the read-out at that concentration, not a potency): 24.3%
For compound 3 the middle estimate is 25.7 percentage points above the measured one; measured number outside the range, below it.
By their numbers in this assay, from the lowest: compound 1; then compound 3; then compound 2.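

The saturated ring carbon turns out to matter as much as the aromatic position did: in this assay, the hydroxy is not a passive feature of the core, since its replacement by hydrogen gives a number 34.4 percentage points lower from compound 2 to compound 3 (beyond the scatter). For the compounds shown here, the earlier pair varied only the aromatic carbon, so this is the first sign that a second site governs the read-out. Nothing available explains the drop.

The compounds shown leave open whether an amine or a methoxy group on that ring carbon would hold the number, and whether hydroxy counts as much with methyl on the aromatic carbon in place of nitro.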